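A few compounds are considered here, and "the series" means these few. Any claim that something is new, unique, unknown or untested is made for them only; others in the source may bear on it.

In an ADME assay on L02 cells (Homo sapiens) for inhibition, read by CCK-8 assay, with a stated time of 48 h (a higher number here means a weaker inhibitor of growth, a lower number a stronger inhibitor of growth), compound 1 (`CN1CCN(c2ccc(Nc3ncc(Cl)c(NCc4ccc(C(F)(F)F)cc4)n3)nc2)CC1`) gives 26200 nM and compound 2 (`COc1ccccc1CNc1nc(Nc2ccc(N3CCN(C)CC3)cn2)ncc1Cl`) gives 25500 nM while compound 3 (`CN1CCN(c2ccc(Nc3ncc(Cl)c(NCc4ccco4)n3)nc2)CC1`) gives 45700 nM and so stands within the scatter of both. The next step leads to compound 4 (`CCc1ccc(Nc2nc(Nc3ccc(N4CCN(C)CC4)cn3)ncc2Cl)cc1`), in which 4-ethylphenyl replaces (furan-2-yl)methyl on a nitrogen on an aromatic ring (4-ethylphenyl in place of (furan-2-yl)methyl on a nitrogen on an aromatic ring). The closest evidence comes from swaps on the saturated chain carbon: a 1.0-fold lower number from compound 1 to compound 2 (0.01 log units; within the scatter) and a 1.7-fold higher number from compound 1 to compound 3 (0.24 log units; within the scatter) and a 1.8-fold higher number from compound 2 to compound 3 (0.25 log units; within the scatter). None of these removes that carbon, so they bear only partly on this change. Still, no step beyond the scatter is expected in this assay. The estimated step is a 1.6-fold lower number from compound 3 to compound 4 (0.21 log units; within the scatter). Compound 4 is expected at 28000 nM with an estimated range of 11000 nM to 60000 nM.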

Compound 4, concentration for 50% growth inhibition: 12100 nM
Compound 4: the middle estimate sits 2.3-fold (0.36 log units) above what was measured; measured number inside the range.
By their numbers in this assay, from the lowest: compound 4; then compounds 2, 1 and 3 (each within the scatter of the next).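

In this assay, going by these compounds alone, the 4-ethylphenyl group on a nitrogen on an aromatic ring gives the first steps beyond the scatter, with a 3.8-fold lower number from compound 3 to compound 4 (0.58 log units; beyond the scatter) and a 2.1-fold lower number from compound 2 to compound 4 (0.32 log units; beyond the scatter) and a 2.2-fold lower number from compound 1 to compound 4 (0.34 log units; beyond the scatter) in this series. Compound 4 is thus the strongest inhibitor of growth of the four, whereas swaps that kept the saturated chain carbon stayed within the scatter. The change removes that carbon and replaces the ring at once, and the compounds shown do not separate these two parts; a 4-ethylbenzyl or an unsubstituted phenyl group on the same nitrogen would. Nothing given here explains the step.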